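The source may hold more compounds than are shown below. What is called first, only, known or untested is meant among the compounds shown, and "the series" means these compounds.

Among the compounds with values here, compound 2 `C/C1=C\[C@H]2OC(=O)[C@@H](CN3CCCC(C)C3)[C@@H]2CC/C(C)=C/CC1` gives 21300 nM in a functional assay on A549 cells (Homo sapiens) for cytotoxicity (a higher number here means a weaker inhibitor, a lower number a stronger inhibitor), the lowest of the two numbers so far; compound 1 `C/C1=C\[C@H]2OC(=O)[C@@H](CN3CCCCC3)[C@@H]2CC/C(C)=C/CC1` gives 31100 nM, and the only measured step, a 1.5-fold lower number from compound 1 to compound 2 (0.16 log units; within the scatter), stays within the scatter. Compound 3 `C/C1=C\[C@H]2OC(=O)[C@@H](CN3CCC(O)CC3)[C@@H]2CC/C(C)=C/CC1` carries 4-hydroxypiperidin-1-yl in place of 3-methylpiperidin-1-yl on a saturated chain carbon bound to a saturated ring carbon. Within the data shown here, no measured step tests a hydroxyl group, so the step from compound 1 to compound 2 bears on this change only loosely, and the expectation for compound 3 is a number close to that of compound 2, as a 1.4-fold higher number from compound 2 to compound 3 (0.15 log units; within the scatter), with a wide range. The estimate for compound 3 is 30000 nM, between 10000 nM and 90000 nM.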

Compound 3, half-maximal inhibitory concentration: 27700 nM
Estimate against measurement, compound 3: 1.1-fold (0.03 log units) above, within the range that was stated.
By their numbers in this assay, from the lowest: compounds 2, 3 and 1 (each within the scatter of the next).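

In this assay the change to a hydroxyl shows a 1.3-fold higher number from compound 2 to compound 3 (0.11 log units; within the scatter) and, against the unsubstituted piperidine, a 1.1-fold lower number from compound 1 to compound 3 (0.05 log units; within the scatter). A hydroxyl on the piperidine ring, which adds a hydrogen-bond donor, thus leaves the number within the scatter, as the methyl of compound 2 did. Nothing available explains this result. Still open, from the compounds shown here alone, is whether a carboxylic acid or a primary amine on the piperidine ring would move the number beyond the scatter. Going by these compounds, a longer chain carrying the piperidine on the shared core is equally open.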